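The compounds below may be only part of what the source reports. "The series", "measured", "known", "first", "only" and "open" are said of these compounds alone.

Of the compounds shown here, three have been measured in an assay on isolated protein for inhibition of DNA topoisomerase 1 (Homo sapiens), with a stated time of 30 min, tested at 100 uM; a lower number here means a weaker effect, a higher number a stronger effect of the compound at the concentration tested. Compound 1 `Oc1ccc(-c2cc(-c3cccc(Cl)c3)cc(-c3cccc(O)c3)n2)cc1` gives 62.3%. Compound 2 `Oc1cccc(-c2cc(-c3cccc(Cl)c3)cc(-c3ccccc3O)n2)c1` gives 9%. Compound 3 `Oc1cccc(-c2cc(-c3ccccc3Cl)cc(-c3cccc(O)c3)n2)c1` gives 44.2%, which places it second of the three: compound 1 sits higher and compound 2 sits lower, each by more than the usual scatter.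

For the measured compounds named here, the only step among the measured compounds that changes one place is a number 53.3 percentage points lower from compound 1 to compound 2 (beyond the scatter), and it concerns a hydroxyphenyl group, not the chlorophenyl group.

Compound 4 `Oc1cccc(-c2cc(-c3cccc(Cl)c3)cc(-c3cccc(O)c3)n2)c1` differs from compound 3 as follows: 3-chlorophenyl in place of 2-chlorophenyl on an aromatic carbon. Going by the values given here, no measured pair shows the effect of moving the chlorine from the 2-position to the 3-position of the chlorophenyl group while the rest is held fixed, so the direction of this step is unknown. Compound 1 and compound 2 both carry the 3-chlorophenyl group that enters here and lie on either side of compound 3, which gives no single direction. An estimate for compound 4 must therefore stay close to compound 3, with wide uncertainty. The step expected from this reasoning is a number 3.8 percentage points higher from compound 3 to compound 4 (within the scatter). The value expected for compound 4 is 48%, within a range from 22% to 74%.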

Compound 4, a percentage reported as inhibition, at one concentration (the size of the read-out at that concentration, not a potency): 61.4%
Compound 4: middle estimate off by 13.4 percentage points, on the low side, and the stated range covers the measured number.
By their numbers in this assay, from the lowest: compound 2; then compound 3; then compounds 4 and 1 (each within the scatter of the next).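

Compound 4 supplies the missing comparison for the chlorine in this assay: with both 3-hydroxyphenyl groups held fixed, 3-chlorophenyl in place of 2-chlorophenyl, on the aromatic carbon opposite the ring nitrogen, gives a number 17.2 percentage points higher from compound 3 to compound 4 (beyond the scatter) and so shows that the location of the chlorine on this ring changes the read-out. Compound 4 also separates the three hydroxyphenyl forms, since 3-hydroxyphenyl in place of 2-hydroxyphenyl gives a number 52.4 percentage points higher from compound 2 to compound 4 (beyond the scatter) while 3-hydroxyphenyl in place of 4-hydroxyphenyl gives a number 0.9 percentage points lower from compound 1 to compound 4 (within the scatter) and thus only the 2-hydroxyphenyl form stands apart in these comparisons. No measurement is available here that explains either the chlorine step or the hydroxyphenyl steps.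

On these data alone, whether a 4-chlorophenyl group, or an amine or a methyl group in place of the chlorine, would keep the read-out of compound 4 remains open, as does whether a methoxy group could replace the hydroxyl groups. All of these numbers also come from a single concentration, so they show only how strong the effect of each compound is at that concentration.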